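The source may report more compounds than this note shows. Statements on the series, on what has been measured and on what is new or still open speak of the compounds shown alone.

Working notes on the series. Compound 1 `Cc1c(C)c2ccc(OCC3CCN(Cc4ccc(CO)cc4)CC3)cc2oc1=O` is the compound with the lowest number among the three measured: in an assay for inhibition of Amine oxidase [flavin-containing] B (Homo sapiens), read by fluorescence, using microsomes, with a stated time of 30 min (a lower number here means a stronger inhibitor, a higher number a weaker inhibitor), compound 1 gives 29 nM. Compound 2 `Cc1cc(=O)oc2cc(OCC3CCN(Cc4ccc(CO)cc4)CC3)ccc12` gives 600 nM in this assay, and compound 3 `Cc1cc(=O)oc2cc(OCC3CCN(Cc4cccc(CO)c4)CC3)ccc12` gives 480 nM. The change from compound 1 to compound 2, hydrogen in place of methyl on an aromatic carbon of the shared core, is a 21-fold higher number from compound 1 to compound 2 (1.32 log units; beyond the scatter). The change from compound 2 to compound 3, 3-(hydroxymethyl)phenyl in place of 4-(hydroxymethyl)phenyl on the saturated chain carbon bound to the amine nitrogen in the ring, is a 1.3-fold lower number from compound 2 to compound 3 (0.10 log units; within the scatter).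

Compound 4 `Cc1c(C)c2ccc(OCC3CCN(CCCCO)CC3)cc2oc1=O` differs from compound 1 at the same position: 3-hydroxypropyl in place of 4-(hydroxymethyl)phenyl on a saturated chain carbon bound to an amine nitrogen in a ring. Among the compounds with values here, of the measured steps only the one from compound 2 to compound 3 touches this position, and it merely moves the hydroxymethyl within the aryl ring without removing the ring; that step was a 1.3-fold lower number from compound 2 to compound 3 (0.10 log units; within the scatter). Within the data shown here, no measured step replaces the aryl by a chain, so the size of this step is not anchored by the data. The expectation for compound 4 is a weaker inhibitor, with a step of a 4.1-fold higher number from compound 1 to compound 4 (0.62 log units; beyond the scatter), and wide uncertainty. Compound 4 is estimated at 120 nM in this assay, within a range of 25 nM to 600 nM.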

Compound 4, half-maximal inhibitory concentration: 3600 nM
Compound 4: middle estimate off by 30-fold (1.48 log units), on the low side, and the stated range ends below it.
By their numbers in this assay, from the lowest: compound 1; then compounds 3 and 2 (each within the scatter of the next); then compound 4.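

In this assay, 3-hydroxypropyl in place of 4-(hydroxymethyl)phenyl on the saturated chain carbon bound to the amine nitrogen in the ring gives a 120-fold higher number from compound 1 to compound 4 (2.09 log units; beyond the scatter). Within the data shown here, this shows that the position is far from indifferent to the group it carries, which the only earlier step here, a 1.3-fold lower number from compound 2 to compound 3 (0.10 log units; within the scatter), could not show, since that step kept the aromatic ring and only moved the hydroxymethyl. The two groups have the same counts of hydrogen-bond donors and acceptors and no net charge, so the large step goes with a difference in heavy atoms and the loss of the six-membered aromatic ring of carbon only, and no measurement at hand explains it.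

The compounds shown leave open whether the aromatic ring itself matters or chain length and bulk are enough, a question that a cyclohexyl group bearing the same hydroxymethyl, or a longer chain ending in hydroxyl, would help to separate. They also leave open whether the hydroxyl contributes at all, which an unsubstituted phenyl on the core of compound 1 would test, and whether the same change has a step of similar size on the core of compound 2.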